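Methylamino at the Ring Position of Compound 3

A few compounds are considered here, and "the series" means these few. Any claim that something is new, unique, unknown or untested is made for them only; others in the source may bear on it.

Compound 3 `O=C(Nc1ccc(-n2ncc3ccccc32)cc1)Nc1ccc(Cl)c(C(F)(F)F)c1` stands, in a functional assay on HepG2 cells (Homo sapiens) for cytotoxicity, read by MTT assay, with a stated time of 72 h (a higher number here means a weaker inhibitor, a lower number a stronger inhibitor), at 8000 nM, level with compound 1 `O=C(Nc1ccc(-n2ncc3c(C(F)(F)F)cccc32)cc1)Nc1ccc(Cl)c(C(F)(F)F)c1` at 8000 nM, the two together the highest numbers among the three. Compound 2 `O=C(Nc1ccc(-n2ncc3c(Br)cccc32)cc1)Nc1ccc(Cl)c(C(F)(F)F)c1` gives 2000 nM in this assay. Compound 4 `CNc1cccc2c1cnn2-c1ccc(NC(=O)Nc2ccc(Cl)c(C(F)(F)F)c2)cc1` carries the change (methylamino in place of hydrogen on an aromatic carbon). Going by the values given here, two measured steps bear on this position: a 4.0-fold higher number from compound 2 to compound 3 (0.60 log units; beyond the scatter), and no change at the digits printed from compound 1 to compound 3 (within the scatter). A group at this position has therefore given either a modest gain or no change beyond the scatter, and a methylamino group is expected to behave in that span, with a modest downward step or none. For compound 4 the estimate in this assay is 5000 nM, with a range from 1500 nM to 15000 nM. This corresponds to an expected step of a 1.6-fold lower number from compound 3 to compound 4 (0.20 log units; within the scatter).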

Compound 4, half-maximal inhibitory concentration: 3000 nM
For compound 4 the middle estimate is 1.7-fold (0.22 log units) above the measured one; low and high end bracket the measured number.
By their numbers in this assay, from the lowest: compounds 2 and 4 (each within the scatter of the next); then compounds 1 and 3 (each within the scatter of the next).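

In this assay, methylamino joins bromo as a second group at this position that departs from hydrogen beyond the scatter, with a 2.7-fold lower number from compound 3 to compound 4 (0.43 log units; beyond the scatter) and, against trifluoromethyl, a 2.7-fold lower number from compound 1 to compound 4 (0.43 log units; beyond the scatter). Against bromo, the reading is a 1.5-fold higher number from compound 2 to compound 4 (0.18 log units; within the scatter), so these two groups are not separated, while trifluoromethyl stays level with hydrogen. Nothing available explains this difference among the groups. Still open, as far as these compounds go, is where a free amine or dimethylamino would fall at this position, and whether a longer chain on the nitrogen would change the number.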